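The source may hold more compounds than are shown below. What is called first, only, known or untested is meant among the compounds shown, and "the series" means these compounds.

Measured in an assay on HEK293 cells for displacement of a labelled ligand from NPC1-like intracellular cholesterol transporter 1 (Homo sapiens); a lower number here means a stronger inhibitor, a higher number a weaker inhibitor:
compound 1 `COC(=O)CCCNC(=O)CN1CN(c2ccccc2)C2(CCN(C(=O)c3ccc(C4CCCCC4)cc3)CC2)C1=O` gives 2500 nM;
compound 2 `COC(=O)CCNC(=O)CN1CN(c2ccccc2)C2(CCN(C(=O)c3ccc(C4CCCCC4)cc3)CC2)C1=O` gives 12900 nM.

For the measured compounds named here, compound 2 gives the higher of the two numbers, with compound 1 its only neighbour, and the step of a 5.2-fold higher number from compound 1 to compound 2 (0.71 log units; beyond the scatter) is the one measured change. Compound 3 `CS(=O)(=O)NCCCNC(=O)CN1CN(c2ccccc2)C2(CCN(C(=O)c3ccc(C4CCCCC4)cc3)CC2)C1=O` differs from compound 2 as follows: (methanesulfonamido)methyl in place of methoxycarbonyl on a saturated chain carbon, two bonds along the chain from an amide-type nitrogen. Going by the values given here, the chain length of compound 3 matches that of compound 1, so the one relevant step, a 5.2-fold higher number from compound 1 to compound 2 (0.71 log units; beyond the scatter), argues for a lower number in this assay; the terminal group itself has no measured precedent. The expected step is a 3.7-fold lower number from compound 2 to compound 3 (0.57 log units; beyond the scatter). For compound 3 the estimate in this assay is 3500 nM, range 1200 nM to 10000 nM.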

Compound 3, half-maximal inhibitory concentration: 3800 nM
The estimate for compound 3 lay 1.1-fold (0.04 log units) below the measured number, and the stated range covers the measured number.
By their numbers in this assay, from the lowest: compounds 1 and 3 (each within the scatter of the next); then compound 2.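

In this assay, (methanesulfonamido)methyl in place of methoxycarbonyl gives a 3.4-fold lower number from compound 2 to compound 3 (0.53 log units; beyond the scatter) and so recovers the number lost on the shorter ester chain. With chain length held equal, methanesulfonamido in place of methoxycarbonyl gives a 1.5-fold higher number from compound 1 to compound 3 (0.18 log units; within the scatter) and leaves the two terminal groups indistinguishable here, so a second end group fits this chain without a measurable change. No available measurement explains these numbers.

From the compounds shown here alone, whether a carboxylic acid or a primary amine at the chain end would match these two groups remains open. So does the effect of a longer chain carrying either the ester or the methanesulfonamido group.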